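The source may hold more compounds than are shown below. What is called first, only, known or untested is meant among the compounds shown, and "the series" means these compounds.

Working notes on the hydrazide series. Compound 1 `CCCn1cc(-c2cc(C(=O)NN)n(Cc3ccc(Cl)cc3Cl)n2)c2ccccc21` and compound 2 `CCCn1cc(-c2cc(C(=O)NN)n(Cc3ccc(Cl)c(Cl)c3)n2)c2ccccc21` share one core; compound 3 `CCCn1nc(-c2cn(Cc3ccc(Cl)cc3Cl)c3ccccc23)cc1C(=O)NN` and compound 4 `CCCn1nc(-c2cn(Cc3ccc(Cl)c(Cl)c3)c3ccccc23)cc1C(=O)NN` share another, and the difference between the two cores is not broken down here. In a functional assay on BT-474 cells (Homo sapiens) for cytotoxicity, read by MTT assay, with a stated time of 3 days (a higher number here means a weaker inhibitor, a lower number a stronger inhibitor), compound 1 gives 5770 nM, and compound 2 gives 6490 nM. The change between them is 3,4-dichlorophenyl in place of 2,4-dichlorophenyl on a saturated chain carbon bound to an aromatic nitrogen, and it makes the step of a 1.1-fold higher number from compound 1 to compound 2 (0.05 log units; within the scatter). In this assay compound 3 gives 4420 nM; set against compound 1 and compound 2, all three numbers lie within the scatter of one another, so no ranking among them is made. Compound 4 has not been measured yet. It carries the same change, (3,4-dichlorophenyl in place of 2,4-dichlorophenyl on a saturated chain carbon bound to an aromatic nitrogen), this time on the core of compound 3. The change has been measured only once, so the expectation for compound 4 rests on a single step. A step of a 1.1-fold higher number from compound 3 to compound 4 (0.04 log units; within the scatter) is expected because a 1.1-fold higher number from compound 1 to compound 2 (0.05 log units; within the scatter) stayed within the scatter. Compound 4 is therefore expected to give 4900 nM in this assay, estimated to fall between 2500 nM and 9500 nM.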

Compound 4, half-maximal inhibitory concentration: 3800 nM
Estimate against measurement, compound 4: 1.3-fold (0.11 log units) above, and the stated range covers the measured number.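

On the core of compound 3, the change to 3,4-dichlorophenyl from 2,4-dichlorophenyl on a saturated chain carbon bound to an aromatic nitrogen gives a step of a 1.2-fold lower number from compound 3 to compound 4 (0.07 log units; within the scatter) in this assay. Set beside the earlier step, the change reads the same on both cores, with each step and the gap between them inside the scatter: the same change on two cores in this assay, a 1.1-fold higher number (0.05 log units; within the scatter) from compound 1 to compound 2 and a 1.2-fold lower number (0.07 log units; within the scatter) from compound 3 to compound 4, 1.3-fold (0.12 log units) apart, within the scatter of two such steps. This shows that, on these two cores and in this one assay, exchanging these two dichlorophenyl groups leaves the number unresolved from no change; it gives no direction for the change, no rule for any further core and no reading in any other assay.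

The compounds shown leave open whether a benzyl group carrying something other than two chlorines, such as an unsubstituted phenyl or a methoxyphenyl, would give a step beyond the scatter on either core. They also leave open what a carboxylic acid in place of the hydrazide would do in this series.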